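Swapping a methoxy for a nitro on an inactive benzylamine

The compounds below may be only part of what the source reports. "The series", "measured", "known", "first", "only" and "open" are said of these compounds alone.

Three compounds share a bicyclic core carrying a methylpyrazole and an amine-linked side group. Compound 1 `CC(Nc1ncnc2ncc(-c3cnn(C)c3)cc12)c1ccncc1` bears a pyridyl-ethyl amine; in a functional assay on MDA-MB-231 cells (Homo sapiens) for antiproliferative activity, read by MTT assay, with a stated time of 72 h (on this read-out higher numbers stand for weaker inhibition and lower numbers for stronger inhibition), compound 1 gives only the assay limit of > 100000 nM, not a number. Compound 2 `CC(Nc1nc(N)nc2ccc(-c3cnn(C)c3)cc12)c1c(Cl)ccc(F)c1Cl` has a different substitution of the core and a dichloro-fluorophenyl group; in this assay compound 2 gives 7960 nM. Compound 3 `COc1cccc(CNc2ncnc3ncc(-c4cnn(C)c4)cc23)c1` carries a 3-methoxyphenyl on a benzylic amine; in this assay compound 3 gives the limit of > 100000 nM, again not a number. Compound 3 thus sits at the limit of > 100000 nM in this assay, at which 2 of the 3 values shown sit.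

Compound 4 `Cn1cc(-c2cnc3ncnc(NCc4cccc([N+](=O)[O-])c4)c3c2)cn1` differs from compound 3 only in one place: nitro in place of methoxy on an aromatic carbon. Read one bond further out, this is 3-methoxyphenyl to 3-nitrophenyl. Within the data shown here, no measured pair shows what such a swap does here, and the nearest comparison, compound 1, also sits at the limit. The step of a number no higher from compound 3 to compound 4 (the limit leaves the size open) is therefore expected to be none beyond the scatter. Compound 4 is expected to give about 100000 nM, between 30000 nM and 300000 nM, most likely again only as a limit.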

Compound 4, half-maximal inhibitory concentration: > 100000 nM
Compound 4: a limit, no number; the forecaster's own chance of this, stated with the estimate: 75%; the middle value sits exactly at the limit.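

Among these compounds, compound 3 and compound 4 each give only a limit in this assay, not a number, and no step between them can be read. The compounds shown leave open what nitro in place of methoxy on an aromatic carbon does to antiproliferative activity.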